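A few compounds are considered here, and "the series" means these few. Any claim that something is new, unique, unknown or untested is made for them only; others in the source may bear on it.

Measured in an assay on isolated protein for inhibition of Rho-associated protein kinase 1 (Homo sapiens), tested at 30 uM; a higher number here means more inhibition at the concentration tested (going by the name of the read-out), a lower number less inhibition:
- compound 1 `c1ccc(Sc2ncnc3[nH]cnc23)cc1` gives 33%
- compound 2 `Fc1ccc(Sc2ncnc3[nH]cnc23)cc1` gives 37%
- compound 3 `Cn1cnc2c(Sc3ccccc3)ncnc21` gives 6%

Compound 3 stands lowest of these three numbers in this assay: its nearest neighbour is compound 1, and a number 27 percentage points lower from compound 1 to compound 3 (beyond the scatter). Within the data shown here, that step, a methyl in place of hydrogen on an aromatic nitrogen, is the only change that moved the read-out beyond the scatter.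

Compound 4 `Cn1cnc2c(Sc3ccc(F)cc3)ncnc21` is not yet measured. It differs from compound 3 in one place: fluoro in place of hydrogen on an aromatic carbon. The same change has been seen once before, between compound 1 and compound 2, where a number 4 percentage points higher from compound 1 to compound 2 (within the scatter). That step bears directly on the present one, and its size was within the scatter. On that single precedent, compound 4 is expected to stay close to compound 3, with the expected step of a number 3 percentage points higher from compound 3 to compound 4 (within the scatter) not clearly beyond the scatter. Compound 4 is therefore estimated at 9% in this assay, within a range from 0% to 22%.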

Compound 4, a percentage reported as inhibition, at one concentration (the size of the read-out at that concentration, not a potency): 6%
Estimate against measurement, compound 4: 3 percentage points above, within the range that was stated.
By their numbers in this assay, from the lowest: compounds 3 and 4 (each within the scatter of the next); then compounds 1 and 2 (each within the scatter of the next).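

In this assay the fluoro change now has a second reading, on the core that carries the methyl, where the step is no change at the digits printed from compound 3 to compound 4 (within the scatter) and so adds nothing measurable there either. Fluoro in place of hydrogen on this aromatic carbon therefore leaves the number in place on both cores: the same change on two cores in this assay, a number 4 percentage points higher (within the scatter) from compound 1 to compound 2 and no change at the digits printed (within the scatter) from compound 3 to compound 4, 4 percentage points apart, within the scatter of two such steps. The methyl in place of hydrogen on the aromatic nitrogen also repeats with fluoro present, as a number 31 percentage points lower from compound 2 to compound 4 (beyond the scatter) on this second pair, so its loss does not depend on which of these two groups sits on the carbon ring: the same change on two cores in this assay, a number 27 percentage points lower (beyond the scatter) from compound 1 to compound 3 and a number 31 percentage points lower (beyond the scatter) from compound 2 to compound 4, 4 percentage points apart, within the scatter of two such steps.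

Only hydrogen and fluoro are shown on this aromatic carbon, so a chloro, a methoxy or an amine there remains an open case. Only hydrogen and methyl are shown on the nitrogen, which leaves open how a longer chain such as propyl would read.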